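A few compounds are considered here, and "the series" means these few. Any claim that something is new, unique, unknown or untested is made for them only; others in the source may bear on it.

Compound 3 `O=C1CSC(c2ccc(F)cc2)N1CCN1CCCCC1` gives 73% in an ADME assay on Vero cells (Chlorocebus sabaeus) for cytotoxicity, read by neutral red uptake, tested at 197 ug/mL (on this read-out lower numbers stand for a stronger effect and higher numbers for a weaker effect at the one concentration tested), and this is the lowest of the three numbers shown: against compound 1 `O=C1CSC(c2cccc(Cl)c2)N1CCN1CCCCC1`, which gives 77%, the gap a number 4 percentage points lower from compound 1 to compound 3 (within the scatter) stays within the scatter, whereas against compound 2 `Cc1ccc(C2SCC(=O)N2CCN2CCCCC2)cc1`, which gives 85%, the gap a number 12 percentage points lower from compound 2 to compound 3 (beyond the scatter) lies beyond it. Compound 4 `O=C1CSC(c2ccc(Cl)cc2)N1CCN1CCCCC1` differs from compound 3 by chloro in place of fluoro on an aromatic carbon, on an aromatic carbon para to a large group. Among the compounds with values here, no measured step exchanges one halogen for another at the same place. The nearest bearing is the step of a number 4 percentage points lower from compound 1 to compound 3 (within the scatter), where a chlorine-bearing ring gave way to a fluorine-bearing one without a change beyond the scatter, and the step of a number 12 percentage points lower from compound 2 to compound 3 (beyond the scatter), which was modest. Compound 4 is therefore expected to return a number close to that of compound 3, with the expected step of a number 3 percentage points higher from compound 3 to compound 4 (within the scatter) lying within the scatter. The estimate for compound 4 in this assay is 76%, with a range from 62% to 90%.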

Compound 4, a percentage reported as activity, at one concentration (the size of the read-out at that concentration, not a potency): 68%
Compound 4: middle estimate off by 8 percentage points, on the high side; measured number inside the range.
By their numbers in this assay, from the lowest: compounds 4, 3, 1 and 2 (each within the scatter of the next, the first and the last beyond it).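

In this assay, within the data shown here, the step of a number 5 percentage points lower from compound 3 to compound 4 (within the scatter) is the first direct exchange of one halogen for another at this place, and it does not separate chloro from fluoro on the aromatic carbon para to a large group. The chlorine's own location is also not separated here, as the step of a number 9 percentage points lower from compound 1 to compound 4 (within the scatter) shows for 4-chlorophenyl against 3-chlorophenyl. Against methyl at the same place, chloro gives the step of a number 17 percentage points lower from compound 2 to compound 4 (beyond the scatter) and so joins fluoro on the far side of the scatter from compound 2, although compound 1 goes against any general split between halogen and methyl, with the step of a number 8 percentage points higher from compound 1 to compound 2 (within the scatter) between them.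

From the compounds shown here alone, whether bromo, methoxy, an amine or a carboxylic acid at this place would stay with the halogens or with methyl remains open. So does the effect of these groups at other places on the ring. No measurement offered here explains any of these steps.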